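This account rests on a few compounds, and the source may have more. Where it says the series, first, only, none or still open, it means among the compounds named here.

This account follows one change within a small set of related compounds. Compound 1 `Cc1ccc(-c2ccnc(Nc3ccc4c(c3)c(/C=C3/C(=O)Nc5ccccc53)cn4C)n2)cc1` carries a methyl group and has no single number in an ADME assay on RWPE-1 cells (Homo sapiens) for cytotoxicity, read by MTT assay, with a stated time of 48 h; on this read-out higher numbers stand for weaker inhibition and lower numbers for stronger inhibition: for compound 1 the result is "not determined" (no result reported), so compound 1 stands on no measured value there. Compound 2 `Cn1cc(/C=C2/C(=O)Nc3ccccc32)c2cc(Nc3nccc(-c4ccc(O)cc4)n3)ccc21` is the hydroxy analogue; in this assay compound 2 gives 58400 nM, a weak effect on these cells. Compound 3 `Cn1cc(/C=C2/C(=O)Nc3ccccc32)c2cc(Nc3nccc(-c4ccc(F)cc4)n3)ccc21` is the compound still to be measured. It differs from compound 1 in one place: fluoro in place of methyl on an aromatic carbon. Among the compounds with values here, no step between measured compounds is available to calibrate this change, and compound 1 itself offers no number to start from. Within the data shown here, with only the single value of compound 2 as a reference, the expectation is that compound 3 remains in the same weak region of this assay, and that any difference from compound 1, had compound 1 been measured, would be of a size not beyond the usual scatter and in no clear direction. For compound 3 the estimated half-maximal inhibitory concentration is 45000 nM, with a range from 15000 nM to 150000 nM.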

Compound 3, half-maximal inhibitory concentration: 168000 nM
Compound 3: middle estimate off by 3.7-fold (0.57 log units), on the low side; measured number outside the range, above it.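

With compound 3, the aromatic carbon para to a large group gains its first readable step: in this assay, fluoro in place of hydroxy gives a 2.9-fold higher number from compound 2 to compound 3 (0.46 log units; beyond the scatter), which shows that the group at this place can shift the read-out in these cells, here towards weaker inhibition. As far as these compounds go, the change this account follows, 4-methylphenyl to 4-fluorophenyl, still cannot be read, since compound 1 has no number to compare with compound 3, and so the effect of fluoro relative to methyl remains unknown. The data shown offer no measurement that bears on the reason for the step from hydroxy to fluoro.

From the compounds shown here alone, two values on one position give a single step and no trend, so it remains open where methyl would fall relative to hydroxy and fluoro, and whether the shift seen here extends to other groups on the same aromatic carbon. An amine, a methoxy group or a carboxylic acid in that place could show whether the read-out follows any order across this position, or whether hydroxy and fluoro are simply two isolated points.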